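This account rests on a few compounds, and the source may have more. Where it says the series, first, only, none or still open, it means among the compounds named here.

Two compounds share one core and differ only in the group on the amide-type nitrogen. Compound 1 `CCOc1nc2cccc(C(=O)N[C@H]3CC[C@H](C(=O)OC)CC3)c2n1Cc1ccc(-c2ccccc2-c2nnn[nH]2)cc1` gives in an assay on isolated protein for inhibition of NEDD8-activating enzyme E1 regulatory subunit (Homo sapiens), read by Western blot, with stated times of 10 min and 30 min, tested at 25 uM (a higher number here means more inhibition at the concentration tested (going by the name of the read-out), a lower number less inhibition), 28.6%, and compound 2 `CCOc1nc2cccc(C(=O)Nc3ccccc3)c2n1Cc1ccc(-c2ccccc2-c2nnn[nH]2)cc1` gives in this assay 34.6%. Of the two numbers shown, that of compound 2 is the higher, with compound 1 as its nearest neighbour, yet the step of a number 6 percentage points higher from compound 1 to compound 2 (within the scatter) lies within the scatter, so the two read alike. Compound 3 `CCOc1nc2cccc(C(=O)NCc3ccccc3)c2n1Cc1ccc(-c2ccccc2-c2nnn[nH]2)cc1` has not yet been measured; it differs from compound 2 by benzyl in place of phenyl on an amide-type nitrogen. Within the data shown here, the only step that touches this place, a number 6 percentage points higher from compound 1 to compound 2 (within the scatter), was small, and it exchanged 4-(methoxycarbonyl)cyclohexyl for phenyl; no measured step here involves a benzyl. The step from compound 2 to compound 3 is therefore expected to be none beyond the scatter, a number 2.6 percentage points lower from compound 2 to compound 3 (within the scatter). For compound 3 a value of 32% is estimated, with a range from 15% to 50%.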

Compound 3, a percentage reported as inhibition, at one concentration (the size of the read-out at that concentration, not a potency): 48.9%
For compound 3 the middle estimate is 16.9 percentage points below the measured one; low and high end bracket the measured number.
By their numbers in this assay, from the lowest: compounds 1 and 2 (each within the scatter of the next); then compound 3.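

In this assay, benzyl in place of phenyl on an amide-type nitrogen gives a number 14.3 percentage points higher from compound 2 to compound 3 (beyond the scatter) and so shows that this position can move the read-out beyond the scatter, which the earlier step did not show. Benzyl in place of 4-(methoxycarbonyl)cyclohexyl gives a number 20.3 percentage points higher from compound 1 to compound 3 (beyond the scatter) and so sets benzyl apart from that group, as phenyl was not, even though phenyl and benzyl each carry one six-membered aromatic ring of carbon only. Nothing measured here speaks to the reason for these steps.

As far as these compounds go, whether a longer chain such as phenethyl would raise the read-out further, or a methoxy group or a chlorine on the benzyl ring would change it, remains open. So does the effect of a carboxylic acid in place of the methyl ester of compound 1, and these single-concentration percentages give no potency for any of the compounds.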